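Lengthening the ester side chain on a weak inhibitor

The compounds below may be only part of what the source reports. "The series", "measured", "known", "first", "only" and "open" are said of these compounds alone.

Compound 1 `CCOC(=O)CCSc1nc2cc(-n3nc(C(C)(C)C)sc3=O)c(F)cc2s1`: 9260 nM
Compound 2 `CCOC(=O)CSc1nc2cc(-n3nc(C(C)(C)C)sc3=O)c(Br)cc2s1`: 15600 nM

Both compounds were tested in an assay on isolated protein for inhibition of protoporphyrinogen oxidase (Homo sapiens), read by capillary electrophoresis; a lower number here means a stronger inhibitor, a higher number a weaker inhibitor. Compound 2 gives the higher of the two numbers, but compound 1 sits within the usual scatter of it, so the two cannot be ordered. Compound 3 `CCOC(=O)CCSc1nc2cc(-n3nc(C(C)(C)C)sc3=O)c(Br)cc2s1` is not yet measured; it differs from compound 2 by (ethoxycarbonyl)methyl in place of ethoxycarbonyl on a saturated chain carbon bound to a sulfur. Among the measured compounds shown here, no measured pair shows this change alone, so the expected step from compound 2 to compound 3 in this assay is a 1.4-fold lower number from compound 2 to compound 3 (0.15 log units; within the scatter), small and not beyond the scatter. Compound 3 is therefore estimated at 11000 nM, within 4000 nM to 30000 nM.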

Compound 3, inhibition constant: 27500 nM
Compound 3: the middle estimate sits 2.5-fold (0.40 log units) below what was measured; measured number inside the range.
By their numbers in this assay, from the lowest: compounds 1, 2 and 3 (each within the scatter of the next, the first and the last beyond it).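

Adding one carbon to the ester chain on the sulfur, with bromo held constant, gives a 1.8-fold higher number from compound 2 to compound 3 (0.25 log units; within the scatter), so in this assay no effect of this change can be read at this position. Among the compounds shown here, with the chain held as 2-(ethoxycarbonyl)ethyl, bromo in place of fluoro on an aromatic carbon gives a 3.0-fold higher number from compound 1 to compound 3 (0.47 log units; beyond the scatter), a modest step, but the first single change here beyond the scatter. Nothing available explains either step.

As far as these compounds go, whether a still longer chain, or a carboxylic acid in place of the ethyl ester, would move the number stays open. So does whether the chain change would read the same with fluoro in place of bromo.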